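This account rests on a few compounds, and the source may have more. Where it says the series, first, only, none or still open, it means among the compounds named here.

Series notes. The three compounds measured share one core; compound 2 `CCOC(=O)N1CCC(NS(=O)(=O)c2ccc(NCc3ccccc3)c3ccccc23)CC1` carries a benzylamino group on it. In an assay on L1.2 cells for binding affinity to C-C chemokine receptor type 8 (Homo sapiens) (on this read-out lower numbers stand for stronger inhibition and higher numbers for weaker inhibition), compound 2 gives 45.6 nM, the lowest of the two numbers recorded. The nearest number belongs to compound 3 `Cc1ccccc1C(=O)Nc1ccc(S(=O)(=O)NC2CCN(C(N)=O)CC2)c2ccccc12`, which in this assay gives 243 nM, a gap beyond the usual scatter. Compound 1 `O=C(Nc1ccc(S(=O)(=O)N2CCCCC2)c2ccccc12)c1ccccc1` gives in this assay only a limit, > 30000 nM, and not a number. the limit of > 30000 nM in this assay, at which 1 of the 3 values shown sits, marks where that limit sits. Going by the values given here, no two measured compounds differ in a single place, so no measured step is available.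

Compound 4 `CCOC(=O)N1CCC(NS(=O)(=O)c2ccc(N)c3ccccc23)CC1` has not yet been measured in this assay. It differs from compound 2 by hydrogen in place of benzyl on a nitrogen on an aromatic ring. Among the compounds with values here, with no measured step to lean on, the size of the change can only be estimated. Taking the number of compound 2, 45.6 nM, as the starting point, a weaker binding is expected for compound 4, and the expected step is a 33-fold higher number from compound 2 to compound 4 (1.52 log units; beyond the scatter), beyond the scatter. For compound 4 in this assay the estimate is 1500 nM, with a range from 200 nM to 15000 nM.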

Compound 4, inhibition constant: > 5000 nM
Compound 4: no number, only a limit; the forecaster's own chance of this, stated with the estimate: 15%; at least 3.3-fold (0.52 log units) between middle value and limit.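

Going by these compounds alone, the step of an at least 100-fold higher number from compound 2 to compound 4 (2.04 log units; beyond the scatter) is the first single-place comparison, and in this assay it shows that binding at this position is highly sensitive to the change from benzylamino to amino. For compound 4 the reading is a limit and not a number: the limit of > 5000 nM in this assay, at which 1 of the 4 values shown sits. Compounds 1 and 3 differ from compound 2 in more than one place, so neither could show what the benzyl group on this nitrogen contributes.

The compounds shown do not settle whether the six-membered aromatic ring of benzyl is what matters or whether any carbon group on this nitrogen would serve, and a methyl, a phenethyl or a cyclohexylmethyl group there would separate these readings. Going by these compounds, whether the same step holds when the rest of the molecule changes also stays open, as a single pair cannot show it.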